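Two dimethoxyphenyl esters and a third awaiting measurement

The source may hold more compounds than are shown below. What is called first, only, known or untested is meant among the compounds shown, and "the series" means these compounds.

Compound 1, `COC(=O)/C(=C\c1ccc(OC(=O)c2cccc(OC)c2)cc1)Sc1ccnc2cc(Cl)ccc12`, in a functional assay on HL-60 cells (Homo sapiens) for cytotoxicity, read by MTT assay, with a stated time of 24 h (on this read-out lower numbers stand for stronger inhibition and higher numbers for weaker inhibition), gives 25500 nM.
Compound 2, `COC(=O)/C(=C\c1ccc(OC(=O)c2c(OC)cccc2OC)cc1)Sc1ccnc2cc(Cl)ccc12`, in this assay gives 37200 nM.

Of the two numbers measured, compound 2 holds the one that reads as the highest, yet the step of a 1.5-fold higher number from compound 1 to compound 2 (0.16 log units; within the scatter) is within the scatter, so compound 2 cannot be told apart from compound 1 on this evidence.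

Compound 3, `COC(=O)/C(=C\c1ccc(OC(=O)c2ccc(OC)cc2OC)cc1)Sc1ccnc2cc(Cl)ccc12`, has not yet been measured. It differs from compound 2 by 2,4-dimethoxyphenyl in place of 2,6-dimethoxyphenyl on a carbonyl carbon. Among the compounds with values here, the only measured step that bears on this change is the one from compound 1 to compound 2, which also exchanged one methoxyphenyl pattern for another on the same carbonyl carbon, and that step was within the scatter. Compound 3 is therefore expected to show no step beyond the scatter in this assay, the expected step being a 1.2-fold lower number from compound 2 to compound 3 (0.07 log units; within the scatter). Compound 3 is estimated at 32000 nM, within a range from 12000 nM to 80000 nM.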

Compound 3, half-maximal inhibitory concentration: 7640 nM
For compound 3 the middle estimate is 4.2-fold (0.62 log units) above the measured one, outside the stated range (below it).
By their numbers in this assay, from the lowest: compound 3; then compounds 1 and 2 (each within the scatter of the next).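

Compound 3 shows that on this carbonyl carbon the arrangement of the methoxy groups can matter in this assay: 2,4-dimethoxyphenyl in place of 2,6-dimethoxyphenyl gives a 4.9-fold lower number from compound 2 to compound 3 (0.69 log units; beyond the scatter) even though the two groups have the same atoms. The earlier pair had shown no step beyond the scatter, whereas 2,4-dimethoxyphenyl in place of 3-methoxyphenyl gives a 3.3-fold lower number from compound 1 to compound 3 (0.52 log units; beyond the scatter) and so sets compound 3 apart from both earlier compounds. Nothing measured here explains the difference.

The three compounds leave open whether a single methoxy group at either place named in 2,4-dimethoxyphenyl would account for the lower number. They also leave open whether a hydroxyl group or an amine could stand in place of a methoxy group on this phenyl ring without losing it.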